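A few compounds are considered here, and "the series" means these few. Any claim that something is new, unique, unknown or untested is made for them only; others in the source may bear on it.

Compound 1, `Brc1cn2ccnc2c(-c2ccc3ncn(C4CCCCC4)c3c2)n1`: in a functional assay on OVCAR-8 cells (Homo sapiens) for inhibition, read by sulforhodamine B assay, with a stated time of 48 h, tested at 10 uM (a lower number here means less inhibition, a higher number more inhibition at the concentration tested (going by the name of the read-out)), compound 1 gives 4.92%.
Compound 2, `COc1ccc(-c2cn3ccnc3c(-c3ccc4ncn(C5CCCCC5)c4c3)n2)cc1`: compound 2 gives 71.2%.
Compound 3, `Fc1ccc(-c2cn3ccnc3c(-c3ccc4ncn(C5CCCCC5)c4c3)n2)cc1`: compound 3 gives 9.54%.

Compound 3 stands second highest of these three numbers. Its nearest neighbour is compound 1, and the step of a number 4.6 percentage points higher from compound 1 to compound 3 (within the scatter) lies within the scatter, so the two cannot be told apart. Compound 2 is far away: the step of a number 61.7 percentage points lower from compound 2 to compound 3 (beyond the scatter) is large and well beyond the scatter.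

Compound 4, `Brc1ccc(-c2cn3ccnc3c(-c3ccc4ncn(C5CCCCC5)c4c3)n2)cc1`, has not yet been measured. It differs from compound 3 in one place: bromo in place of fluoro on an aromatic carbon. Cut one bond further out, the same change reads 4-fluorophenyl to 4-bromophenyl.

Within the data shown here, no measured step swaps bromo for fluoro at this place, so the evidence is indirect. The step of a number 61.7 percentage points lower from compound 2 to compound 3 (beyond the scatter) shows that the group sitting para to the large group can move the number a long way. The step of a number 66.3 percentage points higher from compound 1 to compound 2 (beyond the scatter) is equally large, while a number 4.6 percentage points higher from compound 1 to compound 3 (within the scatter) is small. Bromo at this place is untested, so a modest step in this assay upward is expected, though not confidently beyond the scatter; the estimated step is a number 10.5 percentage points higher from compound 3 to compound 4 (beyond the scatter). Compound 4 is therefore expected to give about 20%, within a range from 0% to 55%.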

Compound 4, a percentage reported as inhibition, at one concentration (the size of the read-out at that concentration, not a potency): 13.2%
Compound 4: middle estimate off by 6.8 percentage points, on the high side; the range from low to high includes it.
By their numbers in this assay, from the lowest: compounds 1, 3 and 4 (each within the scatter of the next); then compound 2.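

In this assay, bromo in place of fluoro on this aromatic carbon, para to a large group, gives a number 3.7 percentage points higher from compound 3 to compound 4 (within the scatter) and so leaves the two compounds indistinguishable. The step of a number 8.3 percentage points higher from compound 1 to compound 4 (within the scatter) shows that 4-bromophenyl, like 4-fluorophenyl, cannot be told apart from the bromo on the core of compound 1, whereas compound 2 goes against this pattern, and the large step of a number 58 percentage points lower from compound 2 to compound 4 (beyond the scatter) sets the methoxy compound clearly apart from the bromo compound at this same place. Nothing available explains why methoxy stands apart from both fluoro and bromo here.

From the compounds shown here alone, it remains open whether the high number depends on the oxygen of methoxy or on the whole group, which a hydroxyl, an ethoxy group or an amine at the same place could help to test. Each number also comes from a single concentration, so these compounds leave open how the inhibition would change at other concentrations.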